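Opening notes on the isoxazolyl-pyrimidinedione series

The source may report more compounds than this note shows. Statements on the series, on what has been measured and on what is new or still open speak of the compounds shown alone.

Measured so far:
- compound 1 `CCCCCc1cc(-c2cn([C@H]3C[C@H](OC(C)=O)[C@@H](COC(C)=O)O3)c(=O)[nH]c2=O)on1`: 91.9%
- compound 2 `CC(=O)OC[C@H]1O[C@@H](n2cc(-c3cc(-c4ccc(C(C)(C)C)cc4)no3)c(=O)[nH]c2=O)C[C@@H]1OC(C)=O`: 32.8%
- compound 3 `CC(C)(C)c1ccc(-c2cc(-c3cn([C@H]4C[C@H](O)[C@@H](CO)O4)c(=O)[nH]c3=O)on2)cc1`: 88%

In a functional assay on NUGC-3 cells (Homo sapiens) for cytotoxicity, read by sulforhodamine B assay, tested at 10 uM (a lower number here means less inhibition, a higher number more inhibition at the concentration tested (going by the name of the read-out)), compound 2 stands lowest of the three numbers, with compound 3 the nearest and compound 1 the furthest, both beyond the scatter.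

Compound 4 `CC(=O)OC[C@H]1O[C@@H](n2cc(-c3cc(C)no3)c(=O)[nH]c2=O)C[C@@H]1OC(C)=O` has not yet been measured in this assay. It differs from compound 2 in one place: methyl in place of 4-(tert-butyl)phenyl on an aromatic carbon.

For the measured compounds named here, one measured step bears on this change. It is a number 59.1 percentage points lower from compound 1 to compound 2 (beyond the scatter), a large fall when a 4-(tert-butyl)phenyl group replaced pentyl on the same aromatic carbon. Compound 4 moves the other way, back to a small alkyl group, so the 4-(tert-butyl)phenyl group that went with the low number of compound 2 is removed. A rise beyond the scatter is therefore expected, though methyl is much shorter than pentyl and a full return to the level of compound 1 is not assured.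

Compound 4 is expected to give 70% in this assay, within 35% to 95%, the estimated step being a number 37.2 percentage points higher from compound 2 to compound 4 (beyond the scatter).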

Compound 4, a percentage reported as inhibition, at one concentration (the size of the read-out at that concentration, not a potency): 90.8%
For compound 4 the middle estimate is 20.8 percentage points below the measured one, within the range that was stated.
By their numbers in this assay, from the lowest: compound 2; then compounds 3, 4 and 1 (each within the scatter of the next).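

In this assay, the aromatic carbon next to the ring nitrogen now has a second alkyl group to compare with the 4-(tert-butyl)phenyl group: the change to methyl gives a number 58 percentage points higher from compound 2 to compound 4 (beyond the scatter), about the same size as the earlier fall in the opposite direction. Shortening the alkyl group from pentyl to methyl gives a number 1.1 percentage points lower from compound 1 to compound 4 (within the scatter), so across these two alkyl groups the chain length makes no difference beyond the scatter. Among compounds 1, 2 and 4, which share the diacetate form, only compound 2 with its 4-(tert-butyl)phenyl group stands apart. No available evidence accounts for this difference. On these data alone, whether the low number follows the benzene ring itself or its tert-butyl group remains open, and a plain phenyl group would separate the two. An amine-bearing chain at this carbon is also untested by the compounds shown.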